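The compounds below may be only part of what the source reports. "The series", "measured", "known", "first", "only" and "open" are said of these compounds alone.

Working notes on the series.

In an ADME assay on THP-1 cells (Homo sapiens) for cytotoxicity, read by flow cytometry and propidium iodide staining, with a stated time of 72 h (on this read-out lower numbers stand for stronger inhibition and higher numbers for weaker inhibition), compound 1 `COc1ccc(-c2cc(=O)c3cc(NC(C)=O)ccc3o2)cc1` gives 74000 nM. Compound 2 `CC(=O)Nc1ccc2oc(-c3ccc(F)cc3)cc(=O)c2c1` differs from compound 1 in one place, (fluoro in place of methoxy on an aromatic carbon), and in this assay compound 2 gives 22000 nM; the change made a 3.4-fold lower number from compound 1 to compound 2 (0.53 log units; beyond the scatter). Compound 3 `COc1ccc(-c2oc3ccc(N)cc3c(=O)c2O)cc1` has a core that differs from that of compound 1; the difference between the two cores is not broken down here. In this assay compound 3 gives 29000 nM, a number within the scatter of that of compound 2 and beyond the scatter against that of compound 1.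

Compound 4 `Nc1ccc2oc(-c3ccc(F)cc3)c(O)c(=O)c2c1` is not yet measured. It differs from compound 3 by fluoro in place of methoxy on an aromatic carbon, the same change as from compound 1 to compound 2, at a place described in the same words. Going by the values given here, the only precedent for this change is a 3.4-fold lower number from compound 1 to compound 2 (0.53 log units; beyond the scatter), a modest step. The expected step is a 3.4-fold lower number from compound 3 to compound 4 (0.53 log units; beyond the scatter), resting on that single precedent and on the value of compound 3. Compound 4 is accordingly expected to give 8500 nM in this assay, estimated between 3500 nM and 20000 nM.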

Compound 4, half-maximal inhibitory concentration: 4000 nM
Estimate against measurement, compound 4: 2.1-fold (0.33 log units) above; measured number inside the range.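

In this assay, fluoro in place of methoxy on an aromatic carbon gives a 7.3-fold lower number from compound 3 to compound 4 (0.86 log units; beyond the scatter), in the same direction as the earlier step, and the two steps agree in size as far as the scatter allows: the same change on two cores in this assay, a 3.4-fold lower number (0.53 log units; beyond the scatter) from compound 1 to compound 2 and a 7.3-fold lower number (0.86 log units; beyond the scatter) from compound 3 to compound 4, 2.2-fold (0.33 log units) apart, within the scatter of two such steps. The change therefore carried over from the core of compound 1 to the core of compound 3 in this assay, and the gap between the two steps gives no ground for calling either core more responsive. This rests on two pairs only, so it does not show that the step would hold on any further core, nor does it say why the number falls.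

The compounds shown leave open whether chloro or ethoxy on that same aromatic carbon would follow fluoro or methoxy. They also leave open whether the step would survive with a carboxylic acid or a longer amide chain in place of the acetamide or the amine.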